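Swapping Bromo for 3-Hydroxy-5-methoxyphenyl on Compound 1

A few compounds are considered here, and "the series" means these few. Any claim that something is new, unique, unknown or untested is made for them only; others in the source may bear on it.

In a functional assay on Jurkat cells (Homo sapiens) for cytotoxicity, with a stated time of 48 h (on this read-out higher numbers stand for weaker inhibition and lower numbers for stronger inhibition), compound 1 `CCOC(=O)CC1C(C(=O)OCC)=C(N)Oc2ccc(Br)cc21` gives 57300 nM. Compound 2 `CC(=O)N(C(C)=O)C1=CC(C)c2cc(-c3ccccc3)ccc2O1` gives 70600 nM, and compound 3 `CCOC(=O)C1=C(N)Oc2ccc(-c3ccccc3)cc2C1CC(=O)N(CC)CC` gives 49600 nM. These three numbers all lie within the scatter of one another, so compound 1 stands level with the other two.

Compound 4 `CCOC(=O)CC1C(C(=O)OCC)=C(N)Oc2ccc(-c3cc(O)cc(OC)c3)cc21` keeps the core of compound 1 but has 3-hydroxy-5-methoxyphenyl in place of bromo on an aromatic carbon. Among the measured compounds shown here, no measured pair isolates this change, so the data offer no direct step to go by. Compound 3, which also carries a phenyl group at that place, reads 49600 nM, and this shows no gap beyond the scatter from compound 1. A large step is therefore not expected. From the compounds shown here alone, the added hydroxy and methoxy groups remain untested here, so a modest move towards a lower number, slightly beyond the scatter, is the working expectation. The estimated change is a 2.1-fold lower number from compound 1 to compound 4 (0.33 log units; beyond the scatter). For compound 4 the expected value is 27000 nM, with an estimated range of 9000 nM to 70000 nM.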

Compound 4, half-maximal inhibitory concentration: 4200 nM
Beside the measured number, compound 4's estimate is 6.4-fold (0.81 log units) above it; measured number outside the range, below it.
By their numbers in this assay, from the lowest: compound 4; then compounds 3, 1 and 2 (each within the scatter of the next).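

In this assay, among the compounds shown here, the swap of bromo for 3-hydroxy-5-methoxyphenyl on this aromatic carbon gives a 14-fold lower number from compound 1 to compound 4 (1.13 log units; beyond the scatter) and so counts as a large step, the first change that stands clear of the scatter. The earlier compounds shown here all read within the scatter of one another and included no pair differing in one place, so they gave no sign that a change at this place could move the number so far. Nothing measured here accounts for the step.

The compounds shown leave open how much of the step belongs to the added ring itself and how much to its hydroxy and methoxy groups. They also leave open whether an amine or a carboxylic acid on that ring would keep the lower number.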